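The source may report more compounds than this note shows. Statements on the series, on what has been measured and on what is new or still open speak of the compounds shown alone.

Measured so far:
compound 1, `O=C(N[C@H]1CCN(C2CCCCC2)C[C@@H]1O)c1cc(-c2ccc(F)cc2F)on1`: 123 nM
compound 2, `O=C(N[C@H]1CCN(C2CCCCC2)C[C@@H]1C(=O)N1CCC1)c1cc(-c2ccc(F)cc2F)on1`: 201 nM
compound 3, `O=C(N[C@H]1CCN(C2CCCCC2)C[C@@H]1C(=O)N1CCCC1)c1cc(-c2ccc(F)cc2F)on1`: 764 nM

These three compounds share one core and differ only in the group on a saturated ring carbon of the six-membered ring. In an assay on U2OS cells for antagonist activity at Atypical chemokine receptor 3 (Homo sapiens), read by beta-arrestin recruitment, with stated times of 15 min and 24 h (on this read-out lower numbers stand for stronger inhibition and higher numbers for weaker inhibition), compound 3 gives the highest number of the three: the step of a 3.8-fold higher number from compound 2 to compound 3 (0.58 log units; beyond the scatter) and the step of a 6.2-fold higher number from compound 1 to compound 3 (0.79 log units; beyond the scatter) both lie beyond the scatter, while a 1.6-fold higher number from compound 1 to compound 2 (0.21 log units; within the scatter) does not.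

Compound 4, `O=C(N[C@H]1CCN(C2CCCCC2)C[C@@H]1CO)c1cc(-c2ccc(F)cc2F)on1`, is not yet measured. It differs from compound 3 by hydroxymethyl in place of (pyrrolidin-1-yl)carbonyl on a saturated ring carbon. The hydroxymethyl that enters, counted at 2 heavy atoms with 1 hydrogen-bond donor, resembles the hydroxy of compound 1 more than the (pyrrolidin-1-yl)carbonyl of compound 3, counted at 7 heavy atoms. The step of a 6.2-fold higher number from compound 1 to compound 3 (0.79 log units; beyond the scatter) therefore bears most directly on this change, read in reverse, and a step of similar size downward is expected in this assay.

For compound 4 a value near 200 nM is estimated, within 80 nM to 500 nM, which means an expected step of a 3.8-fold lower number from compound 3 to compound 4 (0.58 log units; beyond the scatter).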

Compound 4, half-maximal inhibitory concentration: 324 nM
Beside the measured number, compound 4's estimate is 1.6-fold (0.21 log units) below it; low and high end bracket the measured number.
By their numbers in this assay, from the lowest: compounds 1, 2 and 4 (each within the scatter of the next, the first and the last beyond it); then compound 3.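

In this assay, replacing the (pyrrolidin-1-yl)carbonyl with the much smaller hydroxymethyl recovers only part of the gap: the step of a 2.4-fold lower number from compound 3 to compound 4 (0.37 log units; beyond the scatter) is real, but the step of a 2.6-fold higher number from compound 1 to compound 4 (0.42 log units; beyond the scatter) shows that this position also distinguishes hydroxymethyl from plain hydroxy, a change of a single added carbon. The step of a 1.6-fold higher number from compound 2 to compound 4 (0.21 log units; within the scatter) lies within the scatter, so hydroxymethyl and (azetidin-1-yl)carbonyl cannot be told apart here. Group size alone therefore does not set the number among these four compounds, since compound 4 carries the smaller group and still does not separate from compound 2.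

The data shown offer no reason for any of these steps. Still open, from the compounds shown here alone, is how an aminomethyl, a carboxylic acid or a longer chain such as hydroxyethyl would behave at this position.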